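Changing the amide aryl group of a P2X7 antagonist

The source may report more compounds than this note shows. Statements on the series, on what has been measured and on what is new or still open speak of the compounds shown alone.

Measured compounds:
compound 1 `Nc1cccc(S(=O)(=O)Oc2ccc(-c3cncn3C3CCN(C(=O)c4ccc(Cl)c(C(F)(F)F)c4)CC3)cc2)c1` gives 565 nM
compound 2 `O=C(c1ccc(Cl)c(C(F)(F)F)c1)N1CCC(n2cncc2-c2ccc(OS(=O)(=O)c3cccc(Br)c3)cc2)CC1` gives 896 nM
compound 3 `O=C(c1ccc(Cl)c(C(F)(F)F)c1)N1CCC(n2cncc2-c2ccc(OS(=O)(=O)c3cccc4cnccc34)cc2)CC1` gives 45 nM

These three compounds were tested in an assay on HEK293 cells for antagonist activity at P2X purinoceptor 7 (Homo sapiens), read by fluorescence, with a stated time of 2 h; a higher number here means a weaker inhibitor, a lower number a stronger inhibitor. Compound 3 has the lowest number of the three: the change from compound 1 to compound 3 gives a 13-fold lower number from compound 1 to compound 3 (1.10 log units; beyond the scatter), and the change from compound 2 to compound 3 gives a 20-fold lower number from compound 2 to compound 3 (1.30 log units; beyond the scatter). The difference between compound 1 and compound 2, a 1.6-fold higher number from compound 1 to compound 2 (0.20 log units; within the scatter), is not a real change.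

Compound 4 `COc1ccc(C(=O)N2CCC(n3cncc3-c3ccc(OS(=O)(=O)c4cccc5cnccc45)cc3)CC2)cc1` differs from compound 3 at another place: 4-methoxyphenyl in place of 4-chloro-3-(trifluoromethyl)phenyl on a carbonyl carbon. For the measured compounds named here, all measured steps concern the group on the sulfonyl sulfur, so no measured step bears on this change at the carbonyl carbon. Only the general finding that large swings are possible in this series offers guidance, and the direction of this one cannot be read from the data. Compound 4 is therefore expected to be roughly as measured for compound 3 or somewhat weaker, with a wide range, so that a 2.7-fold higher number from compound 3 to compound 4 (0.43 log units; beyond the scatter) is the estimated step. For compound 4 the estimate in this assay is 120 nM, expected between 35 nM and 450 nM.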

Compound 4, half-maximal inhibitory concentration: 77 nM
Compound 4: middle estimate off by 1.6-fold (0.19 log units), on the high side; the measured number falls inside the stated range.
By their numbers in this assay, from the lowest: compounds 3 and 4 (each within the scatter of the next); then compounds 1 and 2 (each within the scatter of the next).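

Replacing 4-chloro-3-(trifluoromethyl)phenyl with 4-methoxyphenyl on the carbonyl carbon gives, in this assay, a 1.7-fold higher number from compound 3 to compound 4 (0.23 log units; within the scatter), so compound 3 and compound 4 cannot be told apart. This is the first step shown at this place, and it indicates that one aryl group can take the place of the other here, with the chlorine and fluorines gone and an oxygen present, without a real change in the number. No measured evidence is available to explain this result.

The compounds shown have only these two aryl groups at this place, so it remains open whether a cyclohexyl group, a longer alkyl chain, or a phenyl ring carrying an amine or a carboxylic acid would also leave the number unchanged. On these data alone, it also remains open whether 4-methoxyphenyl would give the same result with 3-aminophenyl or 3-bromophenyl on the sulfonyl sulfur.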